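A few compounds are considered here, and "the series" means these few. Any claim that something is new, unique, unknown or untested is made for them only; others in the source may bear on it.

Measured compounds:
Compound 1 `O=C(O)c1ccccc1-c1ccc(CCc2ncc(C3CCCCC3)[nH]2)cc1` — 14.7 nM
Compound 2 `O=C(O)c1ccccc1-c1ccc(CCc2ncc(CCc3ccccc3)[nH]2)cc1` — 174 nM
Compound 3 `O=C(O)c1ccccc1-c1ccc(CCc2ncc(CC3CC3)[nH]2)cc1` — 72 nM

In an in vitro functional assay on cells for agonist activity at Bombesin receptor subtype-3 (Mus musculus), read by luminescence and calcium flux (a lower number here means that less compound is needed, a higher number that more compound is needed for the effect), compound 3 stands second highest of the three numbers. Its nearest neighbour is compound 2, with a 2.4-fold lower number from compound 2 to compound 3 (0.38 log units; beyond the scatter); its furthest is compound 1, with a 4.9-fold higher number from compound 1 to compound 3 (0.69 log units; beyond the scatter). The third measured step, a 12-fold higher number from compound 1 to compound 2 (1.07 log units; beyond the scatter), is the largest of the set.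

Compound 4 `CC(C)(C)CCc1cnc(CCc2ccc(-c3ccccc3C(=O)O)cc2)[nH]1` follows from compound 3 by one change: neopentyl in place of cyclopropyl on a saturated chain carbon bound to an aromatic carbon. None of the three measured steps makes exactly this change, so they bear on it only loosely. Replacing cyclohexyl by a group with a chain in it cost a 12-fold higher number from compound 1 to compound 2 (1.07 log units; beyond the scatter) and a 4.9-fold higher number from compound 1 to compound 3 (0.69 log units; beyond the scatter); going from the phenethyl of compound 2 to the cyclopropylmethyl of compound 3 gave a 2.4-fold lower number from compound 2 to compound 3 (0.38 log units; beyond the scatter). Compound 4 carries a group of five carbons with no ring, so by count it sits between the groups of compound 3 and compound 1, and the step is expected to be modest and more likely downward than upward in this assay. The estimate for compound 4 is 45 nM, between 15 nM and 140 nM, which means an expected step of a 1.6-fold lower number from compound 3 to compound 4 (0.20 log units; within the scatter).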

Compound 4, half-maximal effective concentration: 6.2 nM
Compound 4: the middle estimate sits 7.3-fold (0.86 log units) above what was measured, and the stated range ends above it.
By their numbers in this assay, from the lowest: compound 4; then compound 1; then compound 3; then compound 2.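

In this assay, among these compounds, the earlier compounds all carried a ring in the group on this aromatic carbon, and cyclohexyl gave the lowest number among them, yet the ring-free 3,3-dimethylbutyl group goes lower still, with a 2.4-fold lower number from compound 1 to compound 4 (0.37 log units; beyond the scatter) and so a step that lies beyond the scatter. The same group stands far lower than the two groups that link a ring through a chain, with a 12-fold lower number from compound 3 to compound 4 (1.06 log units; beyond the scatter) and with a 28-fold lower number from compound 2 to compound 4 (1.45 log units; beyond the scatter) on exchanging the phenyl at the chain end for tert-butyl, so a ring is not needed here and a chain alone does not set the number, as the high number of compound 2 shows when set beside compound 4. Nothing available explains why this group gives the lowest number of the four.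

The compounds shown leave open whether a straight pentyl chain or an isopropyl end would stand with compound 4 or nearer compound 2, and so whether the tert-butyl end itself matters. They also leave open what a hydroxyl or an amine on this chain would do to the number.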